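Phenyl in Place of Methoxy: Compound 3 to Compound 4

A few compounds are considered here, and "the series" means these few. Any claim that something is new, unique, unknown or untested is made for them only; others in the source may bear on it.

Three measured compounds share one core and differ only in the aromatic ring carried by a saturated chain carbon bound to an oxygen. Compound 1 `CC(C)(N)C(=O)N[C@H](COCc1ccc(F)cc1F)c1nnnn1CCOC(=O)NCCCCO` gives 0.42 nM in a functional assay on cells for inhibition of growth hormone secretagogue receptor type 1 (Homo sapiens), read by FLIPR and calcium flux; a higher number here means that more compound is needed for the effect, a lower number that less compound is needed. Compound 2 `CC(C)(N)C(=O)N[C@H](COCc1cccc(Cl)c1Cl)c1nnnn1CCOC(=O)NCCCCO` gives 0.61 nM in this assay, and compound 3 `COc1ccccc1COC[C@@H](NC(=O)C(C)(C)N)c1nnnn1CCOC(=O)NCCCCO` gives 1.11 nM. Compound 3 therefore holds the highest of the three numbers: its nearest neighbour is reached by a 1.8-fold higher number from compound 2 to compound 3 (0.26 log units; within the scatter), and its furthest by a 2.6-fold higher number from compound 1 to compound 3 (0.42 log units; beyond the scatter).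

Compound 4 `CC(C)(N)C(=O)N[C@H](COCc1ccccc1-c1ccccc1)c1nnnn1CCOC(=O)NCCCCO` is obtained from compound 3 by the change (phenyl in place of methoxy on an aromatic carbon). Each measured step bears on this change, since each one also swaps one substituted phenyl ring for another at the same place: a 1.5-fold higher number from compound 1 to compound 2 (0.16 log units; within the scatter), a 1.8-fold higher number from compound 2 to compound 3 (0.26 log units; within the scatter) and a 2.6-fold higher number from compound 1 to compound 3 (0.42 log units; beyond the scatter). None of those rings brought a second aromatic ring, so the present change goes beyond what the measured steps cover. Given that the earlier swaps moved the number only modestly, a modest further rise is expected, a 1.6-fold higher number from compound 3 to compound 4 (0.21 log units; within the scatter), with wide uncertainty. Compound 4 is thus estimated at 1.8 nM in this assay, with an expected range from 0.6 nM to 6 nM.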

Compound 4, half-maximal effective concentration: 0.34 nM
The estimate for compound 4 lay 5.3-fold (0.72 log units) above the measured number; measured number outside the range, below it.
By their numbers in this assay, from the lowest: compounds 4, 1, 2 and 3 (each within the scatter of the next, the first and the last beyond it).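

In this assay, phenyl in place of methoxy on an aromatic carbon brings a clear change (a 3.3-fold lower number from compound 3 to compound 4 (0.51 log units; beyond the scatter)), which shows that this place can carry a second six-membered aromatic ring, something none of the earlier rings had. The larger group, with six heavy atoms against two, did not raise the number here, although the estimate had assumed a modest rise. The 2-phenylphenyl ring also stands level with the two halogen-bearing rings, 2,3-dichlorophenyl (a 1.8-fold lower number from compound 2 to compound 4 (0.25 log units; within the scatter)) and 2,4-difluorophenyl (a 1.2-fold lower number from compound 1 to compound 4 (0.09 log units; within the scatter)), so its gain over 2-methoxyphenyl brings it into their company and not clearly past them.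

Nothing available explains why the step from methoxy to phenyl runs in this direction. The compounds shown leave open whether an aromatic ring is needed at this place or whether a saturated cyclohexyl ring, a pyridine ring or a simple amine would serve as well, and what a chlorine or a methoxy group on the outer phenyl would do to the number.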